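The source may report more compounds than this note shows. Statements on the series, on what has been measured and on what is new or still open speak of the compounds shown alone.

Measured in a functional assay on A549 cells (Homo sapiens) for antiproliferative activity, read by MTT assay, with a stated time of 72 h; a lower number here means a stronger inhibitor, a higher number a weaker inhibitor:
- Compound 1 `CCCCCCCCNC[C@@H]1OC[C@H](N)[C@@H]1O`: > 128000 nM
- Compound 2 `CCCCCCCCCCCCNC[C@@H]1OC[C@H](N)[C@H]1O`: 41100 nM
- Compound 3 `CCCCCCCCCCCCNC[C@@H]1OC[C@H](N)[C@@H]1O`: 5870 nM

The entry for compound 1, > 128000 nM, is a limit of the assay and not a number. Of the two true numbers, the higher belongs to compound 2, at 41100 nM, and compound 3 lies clearly lower.

Compound 4 `CCCCCCCCCCCNC[C@@H]1OC[C@H](N)[C@H]1O` departs from compound 2 by one change at the end of the chain: hydrogen in place of methyl on a saturated chain carbon, ten or more bonds along the chain from an amine nitrogen. Cut further out, the same difference reads butyl to propyl.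

For the measured compounds named here, two measured steps bear on this. The chain step is an at least 21-fold lower number from compound 1 to compound 3 (1.33 log units; beyond the scatter), and its size rests on (the limit of > 128000 nM in this assay, at which 1 of the 3 values shown sits). Lengthening by butyl thus lowered the number, so a shorter chain should raise it, but compound 4 loses only a methyl, far less than that butyl. That chain step was also seen in the configuration of compound 3, whereas compound 4 keeps that of compound 2. The second step, a 7.0-fold lower number from compound 2 to compound 3 (0.85 log units; beyond the scatter), comes with the fact that compounds 2 and 3 differ only in the configuration as drawn and shows that configuration matters here, so the transfer is uncertain.

A small move toward a higher number in this assay is therefore expected, close to the scatter: the expected step is a 1.8-fold higher number from compound 2 to compound 4 (0.26 log units; within the scatter). The estimate for compound 4 is 75000 nM, with an expected range from 40000 nM to 130000 nM.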

Compound 4, half-maximal inhibitory concentration: 9650 nM
Estimate against measurement, compound 4: 7.8-fold (0.89 log units) above, and the stated range ends above it.
By their numbers in this assay, from the lowest: compounds 3 and 4 (each within the scatter of the next); then compound 2. At a limit, above all of these: compound 1.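

For the compounds shown here, removing one methyl at the end of the chain, on a saturated chain carbon, moved the number in this assay in a direction the earlier compounds did not suggest: a 4.3-fold lower number from compound 2 to compound 4 (0.63 log units; beyond the scatter). This position is therefore sensitive to a single methyl, and here the shorter chain gave the lower number, whereas in the earlier chain pair, read in the other configuration, the longer chain did. Chain length thus has no single direction across the compounds shown, compound 4 being the one that goes against the earlier trend, and the two chain pairs are joined only by a single link between the configurations: the fact that compounds 2 and 3 differ only in the configuration as drawn.

The compounds shown leave open whether the methyl change alone would act the same way in the configuration of compound 3, and whether the number would keep falling or turn upward with a further shortened chain in the configuration of compound 2. They also leave open how a longer chain, or a hydroxyl or a phenyl at the chain end, would read at this position.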